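Swapping the aryl group on a weakly cytotoxic core

The source may report more compounds than this note shows. Statements on the series, on what has been measured and on what is new or still open speak of the compounds shown alone.

Compound 1 `COc1ccccc1Oc1c(N)nc(-c2cccc(C)c2)nc1Cl` gives 65300 nM in a functional assay on A-375 cells (Homo sapiens) for cytotoxicity, read by CCK-8 assay, with a stated time of 24 h; on this read-out lower numbers stand for stronger inhibition and higher numbers for weaker inhibition. Compound 2 `COc1ccccc1Oc1c(N)nc(-c2ccccc2F)nc1Cl` gives only a limit of the assay, > 80000 nM.

Compound 1 holds the only number shown; the other value is a limit. Compound 3 `COc1ccccc1Oc1c(N)nc(-c2ccc(Cl)cc2)nc1Cl` differs from compound 1 by 4-chlorophenyl in place of 3-methylphenyl on an aromatic carbon. Within the data shown here, the one measured step, an at least 1.2-fold higher number from compound 1 to compound 2 (0.08 log units; that floor lies within the scatter), ends at the limit of > 80000 nM in this assay, at which 1 of the 2 values shown sits, and so sets no clear direction. No step beyond the scatter is therefore expected; compound 3 is estimated at 65000 nM, within 20000 nM to 200000 nM, an expected step of a 1.0-fold lower number from compound 1 to compound 3 (0.00 log units; within the scatter).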

Compound 3, half-maximal inhibitory concentration: 1030 nM
The estimate for compound 3 lay 63-fold (1.80 log units) above the measured number; measured number outside the range, below it.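

This position is not indifferent to the aryl group: in this assay, 4-chlorophenyl in place of 3-methylphenyl brings a 63-fold lower number from compound 1 to compound 3 (1.80 log units; beyond the scatter). Set against 2-fluorophenyl, 4-chlorophenyl brings an at least 77-fold lower number from compound 2 to compound 3 (1.89 log units; beyond the scatter). Compound 2 gives only a limit, not a number: the limit of > 80000 nM in this assay, at which 1 of the 3 values shown sits.

From the compounds shown here alone, compound 3 differs from compound 1 in both the substituent and its place on the phenyl ring, and which of the two matters stays open. Also open, going by these compounds, is how a phenyl ring carrying an amine or a carboxylic acid would behave here.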